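The compounds below may be only part of what the source reports. "The series", "measured", "known", "first", "only" and "open" are said of these compounds alone.

Compound 1, `CC(C)(C)C1=NN(c2cccc(F)c2)C(c2ccc(O)cc2)C1`, gives 98.1% in an assay on isolated protein for inhibition of protein kinase C zeta type (Homo sapiens), with a stated time of 4 min, tested at 62.5 uM; a higher number here means more inhibition at the concentration tested (going by the name of the read-out), a lower number less inhibition.
Compound 2, `CC(C)(C)C1=NN(c2ccc(Cl)cc2)C(c2ccc(Cl)cc2)C1`, gives 11.8% in this assay.
Compound 3, `CC(C)(C)C1=NN(c2ccc(Cl)cc2)C(c2ccc(Br)cc2)C1`, gives 39% in this assay.

Compound 3 holds the second highest of the three numbers. For the measured compounds named here, its nearest neighbour is compound 2; the only single-position step among the measured compounds is a number 27.2 percentage points higher from compound 2 to compound 3 (beyond the scatter). Its furthest neighbour is compound 1, which differs from compound 3 in two places, so the two values can only be set side by side: compound 1 gives 98.1%, while compound 3 gives 39%.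

The unmeasured compound 4 is `CC(C)(C)C1=NN(c2ccc(Cl)cc2)C(c2ccc(O)c(Cl)c2)C1`. It differs from compound 3 in one place: 3-chloro-4-hydroxyphenyl in place of 4-bromophenyl on a saturated ring carbon. The step of a number 27.2 percentage points higher from compound 2 to compound 3 (beyond the scatter) concerns the group on this same saturated ring carbon, and it was modest. Going by the values given here, compound 1, the only measured compound whose group on that carbon carries a hydroxyl, gives 98.1%, but its other difference from compound 3 leaves that comparison unresolved. On these grounds a rise in this assay is expected for compound 4, with a number 36 percentage points higher from compound 3 to compound 4 (beyond the scatter) as the expected step. Compound 4 is therefore estimated at 75%, within a range from 45% to 98%.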

Compound 4, a percentage reported as inhibition, at one concentration (the size of the read-out at that concentration, not a potency): 94.5%
Beside the measured number, compound 4's estimate is 19.5 percentage points below it, within the range that was stated.
By their numbers in this assay, from the lowest: compound 2; then compound 3; then compounds 4 and 1 (each within the scatter of the next).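

Until now, this saturated ring carbon, next to the ring nitrogen, had shown only a modest response to exchanging one halogen for another, a number 27.2 percentage points higher from compound 2 to compound 3 (beyond the scatter). In this assay, 3-chloro-4-hydroxyphenyl in place of 4-bromophenyl brings a much larger change, a number 55.5 percentage points higher from compound 3 to compound 4 (beyond the scatter), and the same group in place of 4-chlorophenyl brings a number 82.7 percentage points higher from compound 2 to compound 4 (beyond the scatter), both large and both with the 4-chlorophenyl group on the ring nitrogen held constant. This shows that a change at this one position is enough to take the read-out from the low values of compound 2 and compound 3 to a high value, which compound 1 could not show with its second difference, and nothing measured here speaks to what lies behind this step.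

The hydroxyl and the chlorine enter together, so the compounds shown leave open whether the hydroxyl alone or the chlorine alone would give a step of this size. Also open, from the compounds shown here alone, is how this assay would respond to an amine or a carboxylic acid in place of the hydroxyl on this ring.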